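Swapping Trifluoromethyl for Chloro on the Benzylic Aryl Ring

The compounds below may be only part of what the source reports. "The series", "measured", "known", "first", "only" and "open" are said of these compounds alone.

Three compounds share a core in which a bis(trifluoromethyl)benzenesulfonamide is joined through a three-carbon chain to an amine carrying a benzylic aryl group. In a toxicity assay on MCF-10A cells (Homo sapiens) for inhibition, read by MTT assay, with a stated time of 72 h (on this read-out lower numbers stand for stronger inhibition of growth and higher numbers for weaker inhibition of growth), compound 1 `COc1cccc(CNCCCNS(=O)(=O)c2cc(C(F)(F)F)cc(C(F)(F)F)c2)c1` gives 6600 nM, compound 2 `O=S(=O)(NCCCNCC1COc2ccccc2O1)c1cc(C(F)(F)F)cc(C(F)(F)F)c1` gives 3200 nM, and compound 3 `O=S(=O)(NCCCNCc1ccc(Cl)c(C(F)(F)F)c1)c1cc(C(F)(F)F)cc(C(F)(F)F)c1` gives 7900 nM. Compound 3 stands highest of the three numbers in this assay: the two steps that lead up to it are a 1.2-fold higher number from compound 1 to compound 3 (0.08 log units; within the scatter) and a 2.5-fold higher number from compound 2 to compound 3 (0.39 log units; beyond the scatter).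

Compound 4 `O=S(=O)(NCCCNCc1ccc(Cl)c(Cl)c1)c1cc(C(F)(F)F)cc(C(F)(F)F)c1` differs from compound 3 by chloro in place of trifluoromethyl on an aromatic carbon, so that 4-chloro-3-(trifluoromethyl)phenyl becomes 3,4-dichlorophenyl. Among the measured compounds shown here, no measured step exchanges one substituent for another on this ring; the steps of a 1.2-fold higher number from compound 1 to compound 3 (0.08 log units; within the scatter) and a 2.5-fold higher number from compound 2 to compound 3 (0.39 log units; beyond the scatter) replace the whole aryl group and show at most modest movement. A single-substituent change within a ring of this kind is therefore expected to move this assay by no more than the scatter, and compound 4 is estimated at 7000 nM with a range of 3500 nM to 14000 nM. The expected step is a 1.1-fold lower number from compound 3 to compound 4 (0.05 log units; within the scatter).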

Compound 4, concentration for 50% growth inhibition: 3000 nM
Compound 4: the middle estimate sits 2.3-fold (0.37 log units) above what was measured; the measured number lies below the stated range.
By their numbers in this assay, from the lowest: compounds 4 and 2 (each within the scatter of the next); then compounds 1 and 3 (each within the scatter of the next).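

Within a single aryl ring, chloro in place of trifluoromethyl on this aromatic carbon, ortho to a chloro group, gives a 2.6-fold lower number from compound 3 to compound 4 (0.42 log units; beyond the scatter) in this assay, so one substituent here moves the number about as far as the earlier exchanges of the whole aryl group. The 3,4-dichlorophenyl group also changes how the aryl groups compare: a 1.1-fold lower number from compound 2 to compound 4 (0.03 log units; within the scatter) stays within the scatter, while a 2.2-fold lower number from compound 1 to compound 4 (0.34 log units; beyond the scatter) lies beyond it, although the step from compound 1 to compound 3 did not. Nothing available explains why this exchange moves the number.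

The compounds shown leave open how a fluoro, a methyl or a nitrile on this same carbon would read in this assay. They also leave open whether chloro in place of trifluoromethyl gives a similar step on a ring with no chloro group ortho to it.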